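The source may report more compounds than this note shows. Statements on the series, on what has been measured and on what is new or still open speak of the compounds shown alone.

Among the measured compounds shown here, compound 3 `CC1=C(C(=O)OC2CCC2)C(c2ccsc2)NC(=O)N1` sits second highest of the three numbers measured so far in an assay on membranes from HEK293 cells for displacement of a labelled ligand from adenosine receptor A2b (Homo sapiens), read by scintillation counting, with a stated time of 30 min (a lower number here means a stronger inhibitor, a higher number a weaker inhibitor), where compound 3 gives 405 nM. Its nearest neighbour is compound 1 `CCCOC(=O)C1=C(C)NC(=O)NC1c1ccsc1`; compound 1 gives 201 nM, and the step of a 2.0-fold higher number from compound 1 to compound 3 (0.30 log units; within the scatter) stays within the scatter. Furthest off is compound 2 `CC1=C(C(=O)CC(C)C)C(c2ccsc2)NC(=O)N1`: compound 2 gives 1000 nM, and the step of a 2.5-fold lower number from compound 2 to compound 3 (0.39 log units; beyond the scatter) goes beyond the scatter, as does a 5.0-fold higher number from compound 1 to compound 2 (0.70 log units; beyond the scatter).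

Compound 4 `CC1=C(C(=O)OC2CCCC2)C(c2ccsc2)NC(=O)N1` has not yet been measured. The change from compound 3 is cyclopentyl in place of cyclobutyl on an oxygen next to a carbonyl group: cyclobutyl leaves and cyclopentyl enters, on an oxygen next to a carbonyl group whose other neighbour is the carbonyl carbon; cut one bond further out it reads cyclobutyloxy to cyclopentyloxy.

The step that bears most on this is a 2.0-fold higher number from compound 1 to compound 3 (0.30 log units; within the scatter), which swapped propyl for cyclobutyl on the oxygen next to a carbonyl group and stayed within the scatter. The steps of a 5.0-fold higher number from compound 1 to compound 2 (0.70 log units; beyond the scatter) and a 2.5-fold lower number from compound 2 to compound 3 (0.39 log units; beyond the scatter) changed the group on the carbonyl carbon itself, not the alkyl on the oxygen, and say less. Because a 2.0-fold higher number from compound 1 to compound 3 (0.30 log units; within the scatter) stayed within the scatter, the step of a 1.2-fold lower number from compound 3 to compound 4 (0.06 log units; within the scatter) is expected to be small, none beyond the scatter. Compound 4 is therefore estimated at 350 nM, with a range from 150 nM to 900 nM.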

Compound 4, inhibition constant: 659 nM
Compound 4: middle estimate off by 1.9-fold (0.27 log units), on the low side, within the range that was stated.
By their numbers in this assay, from the lowest: compounds 1, 3, 4 and 2 (each within the scatter of the next, the first and the last beyond it).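

In this assay, putting cyclopentyl in place of cyclobutyl on an oxygen next to a carbonyl group gives a 1.6-fold higher number from compound 3 to compound 4 (0.21 log units; within the scatter) and so does not separate the two rings at this position. Measured against the open propyl group, however, cyclopentyl gives a 3.3-fold higher number from compound 1 to compound 4 (0.52 log units; beyond the scatter) and clears the scatter, whereas cyclobutyl gave a 2.0-fold higher number from compound 1 to compound 3 (0.30 log units; within the scatter) and did not, so only the cyclopentyl ester stands apart from the propyl ester, and only modestly. The new compound also narrows the contrast with the group on the carbonyl carbon: cyclopentyloxy in place of isobutyl gives a 1.5-fold lower number from compound 2 to compound 4 (0.18 log units; within the scatter) and stays within the scatter, while cyclobutyloxy in place of isobutyl gave a 2.5-fold lower number from compound 2 to compound 3 (0.39 log units; beyond the scatter) and went beyond it, so an ester at this place does not in itself set a compound apart from compound 2.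

Nothing in hand accounts for any of these steps. The compounds shown leave open how a longer chain on this oxygen, or a chain ending in an amine or a carboxylic acid, would read in this assay and whether any such group would differ from propyl by more than the scatter.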